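Mirror-image ring stereochemistry in a kinase inhibitor series

The compounds below may be only part of what the source reports. "The series", "measured", "known", "first", "only" and "open" are said of these compounds alone.

Compound 1, `COc1ncc(-c2cc3c(C)nc(N)nc3n([C@H]3CC[C@@H](OCO)CC3)c2=O)cc1F`, is recorded in an assay on BT-20 cells for inhibition of RAC-alpha serine/threonine-protein kinase (Homo sapiens) (on this read-out higher numbers stand for weaker inhibition and lower numbers for stronger inhibition), as "not determined" (no result reported). Compound 2, `Cc1nc(N)nc2c1cc(-c1cn[nH]c1)c(=O)n2[C@H]1CC[C@@H](OCO)CC1`, gives 11.2 nM. Within the data shown here, compound 3, `Cc1nc(N)nc2c1cc(-c1cnc3ccccc3c1)c(=O)n2[C@H]1CC[C@@H](OCO)CC1`, gives 104 nM, the highest of the two numbers available; the one measured step to it, a 9.3-fold higher number from compound 2 to compound 3 (0.97 log units; beyond the scatter), put quinolin-3-yl in place of 1H-pyrazol-4-yl on an aromatic carbon.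

Compound 4, `Cc1nc(N)nc2c1cc(-c1cnc3ccccc3c1)c(=O)n2[C@H]1CC[C@H](OCO)CC1`, keeps every atom and bond of compound 3 and changes only the drawn configuration: the two compounds have the same atoms and bonds and differ only in configuration as drawn: 2 of 2 stereo elements differ (all stereocentres are inverted: mirror images); a stereocentre at a saturated ring carbon is drawn s in compound 3 and r in compound 4; a stereocentre at a saturated ring carbon is drawn s in compound 3 and r in compound 4. Among the measured compounds shown here, the saturated ring carrying the two stereocentres is untouched in all measured pairs, so no measured step speaks to how a mirror-image arrangement of that ring affects the result; the only measured step concerns the aromatic group instead. With no comparable case, the direction of change is open, and a step of either sign beyond the scatter is possible. Compound 4 is therefore estimated at 150 nM, within 30 nM to 800 nM, an expected step of a 1.4-fold higher number from compound 3 to compound 4 (0.16 log units; within the scatter).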

Compound 4, half-maximal inhibitory concentration: 23.8 nM
Beside the measured number, compound 4's estimate is 6.3-fold (0.80 log units) above it; measured number below the stated range.
By their numbers in this assay, from the lowest: compound 2; then compound 4; then compound 3.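

In this assay, a 4.4-fold lower number from compound 3 to compound 4 (0.64 log units; beyond the scatter), so the arrangement of the saturated ring matters in its own right and is not a silent detail of the structure. The earlier measured step changed only the aromatic group, whereas here the quinolin-3-yl group stays fixed and the mirror-image ring arrangement gives the stronger inhibition. This difference can be assigned to the configuration alone, because nothing else separates the pair: the fact that compounds 3 and 4 differ only in the configuration as drawn

As far as these compounds go, both stereocentres are inverted together, so the contribution of each one stays unresolved, and it remains open whether the same inversion would shift the number in the same direction with 1H-pyrazol-4-yl as the aromatic group. From the compounds shown here alone, it is also open whether this preference for one arrangement would hold with an amine or a carboxylic acid as the substituent on the saturated ring.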